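The source may hold more compounds than are shown below. What is called first, only, known or untested is meant among the compounds shown, and "the series" means these compounds.

Compound 2 `COc1ccc(C(c2ccc(OCCO)cc2)c2cccc3ccccc23)c(OC)c1OC` gives 16600 nM in a functional assay on THP-1 cells (Homo sapiens) for inhibition, read by sulforhodamine B assay, with a stated time of 48 h (a lower number here means a stronger inhibitor, a higher number a weaker inhibitor), the only number shown in this series. Compound 1 `COc1ccc(C(OCc2ccccc2)c2cccc3ccccc23)c(OC)c1OC` returns only a limit of > 20000 nM in this assay, a limit (the limit of > 20000 nM in this assay, at which 1 of the 2 values shown sits). The step of an at least 1.2-fold lower number from compound 1 to compound 2 (0.08 log units; that floor lies within the scatter) therefore rests on a floor that lies within the scatter. Compound 3 `COc1ccc(C(c2ccccc2O)c2cccc3ccccc23)c(OC)c1OC` carries 2-hydroxyphenyl in place of 4-(2-hydroxyethoxy)phenyl on a saturated chain carbon bound to two aromatic carbons. Within the data shown here, the one measured step at the same place shows nothing beyond the scatter, so the expected change is a 1.0-fold higher number from compound 2 to compound 3 (0.01 log units; within the scatter), none beyond the scatter. Compound 3 is expected at 17000 nM, within 7000 nM to 40000 nM, with a fair chance of only a limit.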

Compound 3, half-maximal inhibitory concentration: > 20000 nM
Compound 3 was reported as a limit; the forecaster's own chance of this, stated with the estimate: 35%; at least 1.1-fold (0.07 log units) between middle value and limit.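

Putting 2-hydroxyphenyl in place of 4-(2-hydroxyethoxy)phenyl on a saturated chain carbon bound to two aromatic carbons gives an at least 1.2-fold higher number from compound 2 to compound 3 (0.08 log units; that floor lies within the scatter), so no real change can be claimed at this place. The step between compound 1 and compound 3 cannot be read. Compound 2 remains the only compound with a number, and a second compound now sits at the limit: the limit of > 20000 nM in this assay, at which 2 of the 3 values shown sit.

From the compounds shown here alone, whether an amine, a carboxylic acid or a longer chain at this place would give a value beyond the scatter of compound 2 stays open. Going by these compounds, how far compound 3 lies past its limit also stays open.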